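Hydroxy for fluoro on the quaternary carbon

The compounds below may be only part of what the source reports. "The series", "measured", "known", "first", "only" and "open" are said of these compounds alone.

Three compounds carry numbers in a functional assay on HepG2 cells (Homo sapiens) for antiproliferative activity, read by MTT assay, with a stated time of 72 h; a lower number here means a stronger inhibitor, a higher number a weaker inhibitor. Compound 1 `COc1nc(CC(O)(COCc2ccccc2)COCc2ccccc2)c(C)c(OC)n1` gives 2420 nM. Sharing its core with compound 2, compound 3 `COc1nc(=O)n(C)c(CC(O)(COCc2ccccc2)COCc2ccccc2)c1C` gives 33900 nM. Compound 2 `COc1nc(=O)n(C)c(CC(F)(COC(C)=O)COC(C)=O)c1C` reaches only a limit of the assay, > 100000 nM. Among the three values, the limit of > 100000 nM in this assay, at which 1 of the 3 values shown sits, marks where compound 2 stands, with no number of its own.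

Compound 4 `COc1nc(=O)n(C)c(CC(O)(COC(C)=O)COC(C)=O)c1C` is the unmeasured one, and it differs from compound 2 by hydroxy in place of fluoro on a saturated chain carbon bound to three saturated chain carbons. Among the compounds with values here, no pair of measured compounds shows this exact exchange, so its size has to be guessed. Compound 3 carries the same hydroxy on the same core and gives 33900 nM. Compound 2 with fluoro sits at a limit of the assay. A move toward stronger inhibition is therefore expected, though the acetoxymethyl arms of compound 4 are not those of compound 3. The expected step from compound 2 to compound 4 is an at least 1.1-fold lower number from compound 2 to compound 4 (0.04 log units; that floor lies within the scatter), likely beyond the scatter but uncertain. Compound 4 is estimated at 90000 nM, within 25000 nM to 300000 nM.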

Compound 4, half-maximal inhibitory concentration: > 100000 nM
Compound 4: only a limit was reported; the forecaster's own chance of this, stated with the estimate: 50%; at least 1.1-fold (0.04 log units) between middle value and limit.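

In this assay compound 2 and compound 4 both rest at a limit, so no step from one to the other can be read: the limit of > 100000 nM in this assay, at which 2 of the 4 values shown sit.

On these data alone, whether hydroxy in place of fluoro on a saturated chain carbon bound to three saturated chain carbons changes the value at all stays open.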